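Moving the Ring Nitrogen: From Compound 2 to Compound 3

A few compounds are considered here, and "the series" means these few. Any claim that something is new, unique, unknown or untested is made for them only; others in the source may bear on it.

Compound 2 `O=C(N/N=C/c1cccnc1)c1cccnc1Nc1cccc(C(F)(F)F)c1` gives 36% in a functional assay on the whole organism (strain Wistar) for inhibition, with Rattus norvegicus as the target, read by paw edema, with a stated time of 4 h, at a dose of 10 mg/kg by the intraperitoneal route (a higher number here means more inhibition at the dose given (going by the name of the read-out), a lower number less inhibition), the higher of the two numbers recorded so far. Compound 1 `O=C(N/N=C/c1ccc(O)c(O)c1)c1cccnc1Nc1cccc(C(F)(F)F)c1` gives 21.1% in this assay. Among the measured compounds shown here, the single step between them, a number 14.9 percentage points higher from compound 1 to compound 2 (beyond the scatter), is therefore the whole of the measured background.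

Compound 3 `O=C(N/N=C/c1ccncc1)c1cccnc1Nc1cccc(C(F)(F)F)c1` differs from compound 2 in one place: pyridin-4-yl in place of pyridin-3-yl on a carbon with a double bond to nitrogen. For the measured compounds named here, no measured pair shows this particular exchange, and the one step that exists, a number 14.9 percentage points higher from compound 1 to compound 2 (beyond the scatter), swaps a different group at the same carbon, so it gives no direction for the present change. With nothing to point either way, the account expects compound 3 to stay close to compound 2, and the estimated step of a number 1 percentage points lower from compound 2 to compound 3 (within the scatter) is expected to lie within the scatter. Compound 3 is accordingly estimated at 35% in this assay, with a range from 20% to 50%.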

Compound 3, a percentage reported as inhibition, in the whole organism at one dose (the size of the read-out at that dose, not a potency): 45.9%
For compound 3 the middle estimate is 10.9 percentage points below the measured one; low and high end bracket the measured number.
By their numbers in this assay, from the lowest: compound 1; then compounds 2 and 3 (each within the scatter of the next).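

In this assay, pyridin-4-yl in place of pyridin-3-yl gives a number 9.9 percentage points higher from compound 2 to compound 3 (within the scatter), so this measurement does not separate the two pyridine groups at this carbon. With a number 24.8 percentage points higher from compound 1 to compound 3 (beyond the scatter), pyridin-4-yl also stands clear of 3,4-dihydroxyphenyl, so compound 1 now lies beyond the scatter from both compound 2 and compound 3, a pattern that holds for all three compounds shown. Nothing available explains these numbers.

Still open, from the compounds shown here alone, is whether pyridin-2-yl, an unsubstituted phenyl or a pyridine ring carrying an amine would hold the read-out at this carbon. Also open, going by these compounds, is how the shared core would respond if a carboxylic acid stood in place of the trifluoromethyl group.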